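Changing the Side-Chain Ring of Compound 1

The source may report more compounds than this note shows. Statements on the series, on what has been measured and on what is new or still open speak of the compounds shown alone.

Compound 1 `CC(C)C(Nc1nnc[nH]1)c1ccc(-c2ccc3cccc(F)c3c2)[nH]c1=O` and compound 2 `CCC(CC)(c1nnc[nH]1)c1ccc(-c2ccc3cccc(F)c3c2)[nH]c1=O` share one core. In an assay on CHO cells for displacement of a labelled ligand from prostaglandin E2 receptor EP3 subtype (Homo sapiens), read by radioligand binding (on this read-out lower numbers stand for stronger inhibition and higher numbers for weaker inhibition), compound 1 gives 22 nM. Compound 2 gives 19 nM in this assay, so compound 1 carries the higher of the two numbers, though the gap between them lies within the usual scatter. Compound 3 `CC(C)C(c1noc(=O)[nH]1)c1ccc(-c2ccc3cccc(F)c3c2)[nH]c1=O` has not been measured. Relative to compound 1 it carries a group of 6 heavy atoms (2 carbon, 2 nitrogen, 2 oxygen; one five-membered aromatic ring with 3 hetero atoms) in place of a group of 6 heavy atoms (2 carbon, 4 nitrogen; one five-membered aromatic ring with 3 hetero atoms), on a saturated chain carbon bound to an aromatic carbon and a saturated chain carbon. For the measured compounds named here, no measured pair covers this change, so compound 3 is expected to sit a modest step toward a higher number than compound 1, a 2.0-fold higher number from compound 1 to compound 3 (0.31 log units; beyond the scatter). The estimate for compound 3 in this assay is 45 nM, within 12 nM to 170 nM.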

Compound 3, inhibition constant: 15 nM
Beside the measured number, compound 3's estimate is 3.0-fold (0.48 log units) above it; low and high end bracket the measured number.
By their numbers in this assay, from the lowest: compounds 3, 2 and 1 (each within the scatter of the next).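

In this assay, putting the new five-membered aromatic ring in place of the (4H-1,2,4-triazol-3-yl)amino group, on a saturated chain carbon bound to an aromatic carbon and a saturated chain carbon, gives a 1.5-fold lower number from compound 1 to compound 3 (0.17 log units; within the scatter) and so leaves the read-out unresolved from that of compound 1. This position therefore accepts this exchange of one ring group for another without a change that can be told from the scatter. Nothing measured here bears on why the two groups read alike. The compounds shown leave open whether a carboxylic acid or a simple amine at this place would also hold the number. They also leave open whether the same exchange would read alike on a core carrying another aromatic group.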